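Cytotoxicity series: moving a methoxy group on the aryl amine

The source may report more compounds than this note shows. Statements on the series, on what has been measured and on what is new or still open speak of the compounds shown alone.

Compound 1 `COc1ccc(N/C(CCNC2=CC(=O)c3ccccc3C2=O)=N\S(=O)(=O)c2ccc(C)cc2)cc1`: in a functional assay on HeLa cells (Homo sapiens) for cytotoxicity, read by MTT assay, with a stated time of 48 h (a higher number here means a weaker inhibitor, a lower number a stronger inhibitor), compound 1 gives 7590 nM.
Compound 2 `Cc1ccc(S(=O)(=O)/N=C(/CCNC2=CC(=O)c3ccccc3C2=O)Nc2ccc(Cl)cc2)cc1`: compound 2 gives 13400 nM.
Compound 3 `COc1ccc(N/C(CCNC2=CC(=O)c3ccccc3C2=O)=N\S(=O)(=O)c2ccc(C)cc2)cc1OC`: compound 3 gives 14500 nM.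

Compound 3 returns the highest of the three numbers, yet its gaps to the others stay within the scatter: a 1.9-fold higher number from compound 1 to compound 3 (0.28 log units; within the scatter) and a 1.1-fold higher number from compound 2 to compound 3 (0.03 log units; within the scatter). Compound 4 `COc1ccc(N/C(CCNC2=CC(=O)c3ccccc3C2=O)=N\S(=O)(=O)c2ccc(C)cc2)c(OC)c1` differs from compound 3 by 2,4-dimethoxyphenyl in place of 3,4-dimethoxyphenyl on an amine nitrogen. Among the compounds with values here, no measured step moves a group around this ring while keeping the same atoms; the nearest evidence is a 1.9-fold higher number from compound 1 to compound 3 (0.28 log units; within the scatter), which adds a methoxy, and a 1.8-fold higher number from compound 1 to compound 2 (0.25 log units; within the scatter), both within the scatter. All three numbers cluster closely, so no step beyond the scatter is expected in this assay: a 1.2-fold lower number from compound 3 to compound 4 (0.08 log units; within the scatter). Compound 4 is therefore estimated at 12000 nM, range 5000 nM to 30000 nM.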

Compound 4, half-maximal inhibitory concentration: 67600 nM
Beside the measured number, compound 4's estimate is 5.6-fold (0.75 log units) below it; the measured number lies above the stated range.
By their numbers in this assay, from the lowest: compounds 1, 2 and 3 (each within the scatter of the next); then compound 4.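

In this assay, the same atoms rearranged, 2,4-dimethoxyphenyl in place of 3,4-dimethoxyphenyl on the amine nitrogen, produce a step beyond the scatter (a 4.7-fold higher number from compound 3 to compound 4 (0.67 log units; beyond the scatter)), which none of the earlier changes on this ring did. The other steps to this compound are also beyond the scatter (a 5.0-fold higher number from compound 2 to compound 4 (0.70 log units; beyond the scatter)) (an 8.9-fold higher number from compound 1 to compound 4 (0.95 log units; beyond the scatter)), so the methoxy arrangement on this ring matters here, not merely the presence of a second methoxy. No available measurement bears on the reason for this shift.

Still open, on these data alone, is how a hydroxyl, an amine or a carboxylic acid in place of a methoxy on this ring would read. Also open, as far as these compounds go, is whether this step holds in cell lines other than HeLa.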